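A Fluorinated Benzoyl Group on a Flat Series

The source may report more compounds than this note shows. Statements on the series, on what has been measured and on what is new or still open speak of the compounds shown alone.

- Compound 1 (`CC(=O)O[C@H]1CC[C@]2(C)[C@H](CC[C@@](C)(O)[C@H]2CC[C@@H]2C(C)=CC[C@H]3[C@H](CC[C@]3(C)O)C2(C)C)OC1(C)C`) gives 38000 nM in a functional assay on MDA-MB-231 cells (Homo sapiens) for antiproliferative activity, read by MTT assay, with a stated time of 72 h; a higher number here means a weaker inhibitor, a lower number a stronger inhibitor
- Compound 2 (`CC1=CC[C@H]2[C@H](CC[C@]2(C)O)C(C)(C)[C@@H]1CC[C@H]1[C@]2(C)CC[C@H](OC(=O)c3ccccc3[N+](=O)[O-])C(C)(C)O[C@H]2CC[C@@]1(C)O`) gives 38700 nM in this assay

Within the data shown here, the one measured step is a 1.0-fold higher number from compound 1 to compound 2 (0.01 log units; within the scatter) and this places compound 2 level with compound 1, with nothing on these numbers to separate them. Among the measured compounds shown here, compound 3 (`CC1=CC[C@H]2[C@H](CC[C@]2(C)O)C(C)(C)[C@@H]1CC[C@H]1[C@]2(C)CC[C@H](OC(=O)c3ccc(C(F)(F)F)cc3F)C(C)(C)O[C@H]2CC[C@@]1(C)O`) keeps the shared core and differs from compound 2 at that same carbonyl carbon, with 2-fluoro-4-(trifluoromethyl)phenyl in place of 2-nitrophenyl (2-fluoro-4-(trifluoromethyl)phenyl in place of 2-nitrophenyl on a carbonyl carbon) as its single change. The measured step bears directly on this site, since a far smaller group and an aromatic one gave values within the scatter of each other there. Going by these compounds, neither measured compound carries fluorine, however, so the entering group itself remains untested, and one flat step is thin evidence. No shift beyond the scatter is therefore expected, and the estimated change is a 1.1-fold lower number from compound 2 to compound 3 (0.04 log units; within the scatter) in this assay on this reasoning. For compound 3 the estimated value is 35000 nM (range 15000 nM to 75000 nM) in a measurement still to come.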

Compound 3, half-maximal inhibitory concentration: 36300 nM
Compound 3: middle estimate off by 1.0-fold (0.02 log units), on the low side; the range from low to high includes it.
By their numbers in this assay, from the lowest: compounds 3, 1 and 2 (each within the scatter of the next).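

Placing 2-fluoro-4-(trifluoromethyl)phenyl on the carbonyl carbon in place of 2-nitrophenyl gives a 1.1-fold lower number from compound 2 to compound 3 (0.03 log units; within the scatter) in this assay, so a fluorine-bearing group, untested in the earlier pair, now reads level with a nitro-bearing one at this site. Set against methyl, the same group gives a 1.0-fold lower number from compound 1 to compound 3 (0.02 log units; within the scatter), which means that methyl and both substituted phenyl groups now lie within the scatter of one another at this position, and the flat picture no longer rests on a single step. Nothing measured here explains why the three values lie so close together.

The compounds shown carry only methyl and these two substituted phenyl groups on this carbonyl carbon, so it remains open what an amine, a carboxylic acid or a longer alkyl chain would do there. All three also share the same core, which leaves open whether a change elsewhere in it would move the number in this assay at all, given that this site has so far shown no step beyond the scatter.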